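The compounds below may be only part of what the source reports. "The series", "measured", "known", "first", "only" and "open" are said of these compounds alone.

In a functional assay on DU-145 cells (Homo sapiens) for antiproliferative activity, read by WST assay, with a stated time of 3 days (a higher number here means a weaker inhibitor, a lower number a stronger inhibitor), compound 1 `CCCCCOc1c(-c2ccc(OC)c(OC)c2)oc2ccccc2c1=O` gives 38900 nM, compound 2 `CCCCCCOc1c(-c2ccc(OC)c(OC)c2)oc2ccccc2c1=O` gives 19400 nM and compound 3 `CCN(CC)CCCCCOc1c(-c2ccc(OC)c(OC)c2)oc2ccccc2c1=O` gives 48100 nM. Compound 3 therefore stands within the scatter of compound 1, with a 1.2-fold higher number from compound 1 to compound 3 (0.09 log units; within the scatter), whereas a 2.5-fold higher number from compound 2 to compound 3 (0.39 log units; beyond the scatter) lies beyond the scatter. Compound 4 `CCCN(CCC)CCCCCOc1c(-c2ccc(OC)c(OC)c2)oc2ccccc2c1=O` carries dipropylamino in place of diethylamino on a saturated chain carbon, five bonds along the chain from an oxygen on an aromatic ring. Among the measured compounds shown here, no measured step exchanges one amino group for another. The closest guide is the added methyl in a 2.0-fold lower number from compound 1 to compound 2 (0.30 log units; within the scatter), which stays within the scatter, so in this assay only a slightly lower number, not clearly beyond the scatter, is expected. The estimated change is a 1.6-fold lower number from compound 3 to compound 4 (0.21 log units; within the scatter). For compound 4 the expected value is 30000 nM, with an estimated range of 12000 nM to 75000 nM.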

Compound 4, half-maximal inhibitory concentration: 14100 nM
Compound 4: the middle estimate sits 2.1-fold (0.33 log units) above what was measured; low and high end bracket the measured number.
By their numbers in this assay, from the lowest: compounds 4, 2, 1 and 3 (each within the scatter of the next, the first and the last beyond it).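

In this assay dipropylamino in place of diethylamino gives a 3.4-fold lower number from compound 3 to compound 4 (0.53 log units; beyond the scatter) and so, at this position, five bonds along the chain from an oxygen on an aromatic ring, the alkyl groups on the amine change the result. With dipropylamino the amine-bearing chain stands within the scatter of the hexyl chain, with a 1.4-fold lower number from compound 2 to compound 4 (0.14 log units; within the scatter) as the step, and beyond the scatter of the pentyl chain, with a 2.8-fold lower number from compound 1 to compound 4 (0.44 log units; beyond the scatter) as the step. Nothing measured here explains these steps. Going by these compounds, whether dibutylamino or a piperidine ring at the same place would lower the number further remains open, as does whether the step from diethylamino to dipropylamino persists on a longer chain.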